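This account rests on a few compounds, and the source may have more. Where it says the series, first, only, none or still open, it means among the compounds named here.

Working notes on the series. Compound 1 `CC(=O)Nc1ccc(-n2nncc2CN2C(=O)C3(C(C#N)=C(N)Oc4c3c3nc5ccccc5nc3c3ccccc43)c3ccccc32)cc1`, compound 2 `N#CC1=C(N)Oc2c(c3nc4ccccc4nc3c3ccccc23)C12C(=O)N(Cc1cnnn1-c1ccc(Cl)c(Cl)c1)c1ccccc12` and compound 3 `N#CC1=C(N)Oc2c(N)cc3nc4ccccc4nc3c2C12C(=O)N(Cc1cnnn1-c1ccccc1Cl)c1ccccc12` share one core and differ only in the aryl group on the triazole nitrogen. In an ADME assay on L02 cells (Homo sapiens) for antiproliferative activity, read by MTT assay, with a stated time of 48 h (on this read-out higher numbers stand for weaker inhibition and lower numbers for stronger inhibition), compound 1 gives only the assay limit, > 50000 nM. Compound 2 also returns only the limit in this assay, > 50000 nM. Compound 3 likewise sits at the limit in this assay, > 50000 nM. The step that the two limits leave unreadable from compound 1 to compound 2 is thus not readable, and the limit of > 50000 nM in this assay, at which 3 of the 3 values shown sit, covers every value shown. Compound 4 `CCOc1ccc(-n2nncc2CN2C(=O)C3(C(C#N)=C(N)Oc4c(N)cc5nc6ccccc6nc5c43)c3ccccc32)cc1` differs from compound 3 by 4-ethoxyphenyl in place of 2-chlorophenyl on an aromatic nitrogen. No readable measured step bears on this change, and compound 3 offers no number to move from. The expected step is a step that the limit leaves unreadable from compound 3 to compound 4, nothing beyond the scatter. Compound 4 is estimated at 80000 nM in this assay, between 30000 nM and 300000 nM, most likely again reported only as a limit.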

Compound 4, half-maximal inhibitory concentration: > 50000 nM
Compound 4 was reported as a limit; the forecaster's own chance of this, stated with the estimate: 85%; the middle value lies beyond the limit too.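

No new step can be read between compound 3 and compound 4 in this assay, as both are reported only as a limit: the limit of > 50000 nM in this assay, at which 4 of the 4 values shown sit. What the aryl group on the triazole nitrogen does in this assay remains open for the compounds shown.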